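The compounds below may be only part of what the source reports. "The series", "measured", "known", "first", "only" and "open" are said of these compounds alone.

Among the measured compounds shown here, compound 3 `COc1cc(N(C)CCN(C)C)c(NC(=O)c2ccnc(O)c2)cc1Nc1nccc(-c2cn(C)c3ccccc23)n1` is one of three compounds measured in a functional assay on A549 cells (Homo sapiens) for antiproliferative activity, read by MTT assay, with a stated time of 72 h; a higher number here means a weaker inhibitor, a lower number a stronger inhibitor. In this assay compound 3 gives 11200 nM. Compound 2 `COc1cc(F)c(NC(=O)c2ccnc(O)c2)cc1Nc1nccc(-c2cn(C)c3ccccc23)n1` gives 11700 nM in this assay, and the step of a 1.0-fold lower number from compound 2 to compound 3 (0.02 log units; within the scatter) leaves the two numbers indistinguishable. Compound 1 `COc1cc(F)c(NC(=O)c2ccnc(Cl)c2)cc1Nc1nccc(-c2cn(C)c3ccccc23)n1` gives 6890 nM in this assay, with the step of a 1.7-fold higher number from compound 1 to compound 2 (0.23 log units; within the scatter). All three numbers thus sit within the scatter of one another, and compound 3 stands nowhere apart from the other two.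

Compound 4 `COc1cc(N(C)CCN(C)C)c(NC(=O)c2ncccn2)cc1Nc1nccc(-c2cn(C)c3ccccc23)n1` differs from compound 3 in one place: pyrimidin-2-yl in place of 2-hydroxypyridin-4-yl on a carbonyl carbon. Neither measured step reproduces this change. The nearest comparison is the exchange on the same ring that sits on the carbonyl carbon, where a 1.7-fold higher number from compound 1 to compound 2 (0.23 log units; within the scatter) was found, which is nothing beyond the scatter; the other step, a 1.0-fold lower number from compound 2 to compound 3 (0.02 log units; within the scatter), concerns a different part of the molecule and was flat as well. Because neither a 1.7-fold higher number from compound 1 to compound 2 (0.23 log units; within the scatter) nor a 1.0-fold lower number from compound 2 to compound 3 (0.02 log units; within the scatter) shifted the number, the expectation for compound 4 is a step within the scatter, with no direction claimed, estimated as a 1.1-fold lower number from compound 3 to compound 4 (0.05 log units; within the scatter). Compound 4 is therefore estimated at 10000 nM in this assay, with a range from 4000 nM to 25000 nM.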

Compound 4, half-maximal inhibitory concentration: 2490 nM
Beside the measured number, compound 4's estimate is 4.0-fold (0.60 log units) above it; the measured number lies below the stated range.
By their numbers in this assay, from the lowest: compound 4; then compounds 1, 3 and 2 (each within the scatter of the next).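

In this assay the group on the carbonyl carbon proves to be a place where the number can move, since pyrimidin-2-yl in place of 2-hydroxypyridin-4-yl gives a 4.5-fold lower number from compound 3 to compound 4 (0.65 log units; beyond the scatter), the only step among these compounds that lies beyond the scatter. The earlier exchange of chloro for hydroxy on the ring at this carbonyl carbon gave a 1.7-fold higher number from compound 1 to compound 2 (0.23 log units; within the scatter), so that smaller change had not revealed that replacing the ring itself could shift the result. The replacement goes from 1 hydrogen-bond donor to 0 and from 1 ring hetero atom to 2 at once, and no evidence here bears on which of these differences, if either, accounts for the result.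

From the compounds shown here alone, it remains open whether pyrimidin-2-yl would give a similar step in a compound carrying fluoro in place of the (2-(dimethylamino)ethyl)(methyl)amino group. Going by these compounds, it is also open whether the result is specific to pyrimidin-2-yl or would extend to another ring on the carbonyl carbon, such as pyrazin-2-yl or pyridin-2-yl.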